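Propyl in place of methyl on the ring of compound 1

A few compounds are considered here, and "the series" means these few. Any claim that something is new, unique, unknown or untested is made for them only; others in the source may bear on it.

Measured in a functional assay on M21 cells (Homo sapiens) for antiproliferative activity, read by sulforhodamine B assay, with a stated time of 48 h; a higher number here means a weaker inhibitor, a lower number a stronger inhibitor:
- compound 1 `CCc1ccccc1OS(=O)(=O)c1ccc(N2CCN(C)C2=O)cc1`: 2300 nM
- compound 2 `CN1CCN(c2ccc(S(=O)(=O)Oc3cccc(Cl)c3)cc2)C1=O`: 1600 nM

For the measured compounds named here, compound 1 has the higher of only two numbers, but the measured step, a 1.4-fold lower number from compound 1 to compound 2 (0.16 log units; within the scatter), lies within the scatter, so the two stand level. Compound 3 `CCCN1CCN(c2ccc(S(=O)(=O)Oc3ccccc3CC)cc2)C1=O` differs from compound 1 by ethyl in place of hydrogen on a saturated chain carbon bound to an amide-type nitrogen in a ring, that is, methyl to propyl. Going by the values given here, the one measured step concerns a different place and does not bear directly on this change. No shift beyond the scatter is therefore expected in this assay, and neither direction is favoured. The expected step is a 1.1-fold higher number from compound 1 to compound 3 (0.04 log units; within the scatter). Compound 3 is estimated at 2500 nM, within a range of 800 nM to 7000 nM.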

Compound 3, half-maximal inhibitory concentration: > 50000 nM
Compound 3: no number, only a limit; the forecaster's own chance of this, stated with the estimate: 3%; at least 20-fold (1.30 log units) between middle value and limit.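

In this assay, extending methyl to propyl, with ethyl entering on the saturated chain carbon bound to an amide-type nitrogen in a ring, gives an at least 21-fold higher number from compound 1 to compound 3 (1.33 log units; beyond the scatter). The earlier step at the oxygen, a 1.4-fold lower number from compound 1 to compound 2 (0.16 log units; within the scatter), stayed within the scatter, so this is the first change shown to move the read-out beyond it. For compound 3 the reading is a limit, not a number: the limit of > 50000 nM in this assay, at which 1 of the 3 values shown sits.

On these data alone, whether an ethyl chain in place of methyl is tolerated remains open. Also open, as far as these compounds go, is whether a terminal amine or hydroxyl on the propyl chain would give a different result.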